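From a Fluorophenyl Sulfonamide to Its Methoxyphenyl Analogue

The source may report more compounds than this note shows. Statements on the series, on what has been measured and on what is new or still open speak of the compounds shown alone.

Compound 1 `O=S(=O)(Nc1ccc2oc(-c3ccccc3)nc2c1)c1cccc(F)c1` was tested in an assay on cells for inhibition of HSP60/HSP10 (Homo sapiens), with a stated time of 60 min; on this read-out lower numbers stand for stronger inhibition and higher numbers for weaker inhibition. In this assay compound 1 gives only a limit, > 100000 nM. Compound 2 `CS(=O)(=O)Nc1ccc(-c2nc3ccccc3o2)cc1` likewise gives a limit in this assay, > 100000 nM. Compound 3 `O=S(=O)(Nc1ccc(-c2nc3ccccc3o2)cc1)c1ccccc1O` also gives a limit, > 100000 nM. The step that the two limits leave unreadable from compound 2 to compound 3, 2-hydroxyphenyl in place of methyl on a sulfonyl sulfur, therefore cannot be read. All three values sit at the limit of > 100000 nM in this assay, at which 3 of the 3 values shown sit. Compound 4 `COc1ccc(S(=O)(=O)Nc2ccc3oc(-c4ccccc4)nc3c2)cc1` differs from compound 1 by 4-methoxyphenyl in place of 3-fluorophenyl on a sulfonyl sulfur, on a sulfonyl sulfur whose other neighbour is the sulfonamide nitrogen. Going by the values given here, no measured step bears on this change, and every value shown is a limit, so no step beyond the scatter is expected in either direction. Compound 4 is therefore estimated at 150000 nM, between 40000 nM and 600000 nM, most likely again a limit, the expected step being a step that the limit leaves unreadable from compound 1 to compound 4.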

Compound 4, half-maximal inhibitory concentration: > 100000 nM
Compound 4 was reported as a limit; the forecaster's own chance of this, stated with the estimate: 85%; the middle value lies beyond the limit too.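

Compound 1 and compound 4 both give only a limit, so no step can be read between them. The compounds shown leave open whether any group on the sulfonyl sulfur gives a measurable value in this assay.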